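Swapping the (pyridin-2-yl)amino group for ureido

The source may hold more compounds than are shown below. What is called first, only, known or untested is meant among the compounds shown, and "the series" means these compounds.

Of the compounds shown here, three sharing one core have been tested in a functional assay on NB1 cells (Homo sapiens) for cytotoxicity, read by MTT assay, with a stated time of 3 days; on this read-out lower numbers stand for stronger inhibition and higher numbers for weaker inhibition. Compound 1 (`N#Cc1c(O)nc(SCc2nc3ccccc3[nH]2)nc1-c1ccccc1`) gives 6.57 nM, compound 2 (`CNc1nc(SCc2nc3ccccc3[nH]2)nc(-c2ccccc2)c1C#N`) gives 4.46 nM, and compound 3 (`N#Cc1c(Nc2ccccn2)nc(SCc2nc3ccccc3[nH]2)nc1-c1ccccc1`) gives 3.9 nM. Compound 3 therefore stands within the scatter of both others.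

The next compound, compound 4 (`N#Cc1c(NC(N)=O)nc(SCc2nc3ccccc3[nH]2)nc1-c1ccccc1`), carries carbamoyl in place of pyridin-2-yl on a nitrogen on an aromatic ring, which turns (pyridin-2-yl)amino into ureido: carbamoyl in place of pyridin-2-yl on a nitrogen on an aromatic ring. The closest measured change is a 1.1-fold lower number from compound 2 to compound 3 (0.06 log units; within the scatter), made on the same nitrogen. Changing the whole group at this place gave a 1.5-fold lower number from compound 1 to compound 2 (0.17 log units; within the scatter) and a 1.7-fold lower number from compound 1 to compound 3 (0.23 log units; within the scatter). Going by the values given here, all three steps lie within the scatter, although no measured compound yet carries a carbamoyl group. No shift beyond the scatter is therefore expected in this assay, and the expected change is small: a 1.2-fold higher number from compound 3 to compound 4 (0.06 log units; within the scatter). Compound 4 is estimated at 4.5 nM, with an expected range of 2 nM to 10 nM.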

Compound 4, half-maximal inhibitory concentration: 7.35 nM
For compound 4 the middle estimate is 1.6-fold (0.21 log units) below the measured one; the range from low to high includes it.
By their numbers in this assay, from the lowest: compounds 3, 2, 1 and 4 (each within the scatter of the next).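

In this assay the carbamoyl group, with no ring and one hydrogen-bond donor, stands on this nitrogen in place of the aromatic pyridin-2-yl without leaving the scatter (a 1.9-fold higher number from compound 3 to compound 4 (0.28 log units; within the scatter)). The same holds against the smaller methyl on that nitrogen (a 1.6-fold higher number from compound 2 to compound 4 (0.22 log units; within the scatter)) and against the hydroxy group on the aromatic carbon (a 1.1-fold higher number from compound 1 to compound 4 (0.05 log units; within the scatter)), so hydroxy, methylamino, (pyridin-2-yl)amino and ureido cannot be told apart at this place in this read-out. No measured property bears on this result, and the numbers alone give no reason for it.

From the compounds shown here alone, whether a free amine, a carboxylic acid or a longer alkylamino chain at this place would move the number beyond the scatter stays open. Also open, going by these compounds, is whether this insensitivity would hold with changes elsewhere on the shared core.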